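Series notes: urea to benzamide on the shared core

The source may hold more compounds than are shown below. What is called first, only, known or untested is meant among the compounds shown, and "the series" means these compounds.

Compound 2 `COc1cc(Cl)cc(-c2nn(-c3cccc(NC(=O)Nc4ccc(Cl)c(Cl)c4)c3)cc2-c2ccncc2)c1` and compound 1 `O=C(Nc1cccc(-n2cc(-c3ccncc3)c(-c3cc(O)cc(Cl)c3)n2)c1)Nc1ccc(Cl)c(Cl)c1` share one core and differ only by methyl in place of hydrogen on an oxygen on an aromatic ring. In a functional assay on SN12C cells (Homo sapiens) for inhibition, read by sulforhodamine B assay, with a stated time of 48 h, tested at 10 uM (a lower number here means a stronger effect, a higher number a weaker effect of the compound at the concentration tested), compound 2 gives 15.5%, and compound 1 gives 14.9%; the step of a number 0.6 percentage points higher from compound 1 to compound 2 (within the scatter) lies within the scatter, so the two stand together. Compound 3 `COc1cc(Cl)cc(-c2nn(-c3cccc(NC(=O)c4cccc(C(F)(F)F)c4)c3)cc2-c2ccncc2)c1` takes a different route: 3-(trifluoromethyl)phenyl in place of (3,4-dichlorophenyl)amino on a carbonyl carbon. Going by the values given here, no measured step touches a carbonyl carbon whose other neighbour is an amide-type nitrogen, so no measured step bears on it. Compound 3 is expected to lose some effect, estimated at 32%, between 10% and 70%, a step of a number 16.5 percentage points higher from compound 2 to compound 3 (beyond the scatter).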

Compound 3, a percentage reported as activity, at one concentration (the size of the read-out at that concentration, not a potency): 65.9%
For compound 3 the middle estimate is 33.9 percentage points below the measured one, within the range that was stated.
By their numbers in this assay, from the lowest: compounds 1 and 2 (each within the scatter of the next); then compound 3.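

In this assay, going by these compounds alone, the carbonyl carbon is far less forgiving than the oxygen on the aromatic ring: replacing (3,4-dichlorophenyl)amino with 3-(trifluoromethyl)phenyl there gives a number 50.4 percentage points higher from compound 2 to compound 3 (beyond the scatter), whereas the one earlier step lay within the scatter. This single swap removes the amino nitrogen and changes the ring substituents together, so the step cannot be assigned to either alone. Nothing at hand accounts for the size of this step.

Still open, on these data alone, is which of the two changes carries the loss. A methylene linker on the carbonyl carbon, keeping the 3,4-dichlorophenyl ring, would help separate them.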